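A few compounds are considered here, and "the series" means these few. Any claim that something is new, unique, unknown or untested is made for them only; others in the source may bear on it.

Compound 1, `COc1ccccc1C[C@H]1COC(=O)[C@@H]1Cc1ccc(Cl)c(Cl)c1`: in a functional assay on HL-60 cells (Homo sapiens) for cytotoxicity, read by WST assay, with a stated time of 48 h (a lower number here means that less compound is needed, a higher number that more compound is needed for the effect), compound 1 gives 14000 nM.
Compound 2, `Cc1ccccc1C[C@H]1COC(=O)[C@@H]1Cc1ccc(Cl)c(Cl)c1`: in this assay compound 2 gives 22000 nM.
Compound 3, `COc1ccc(C[C@H]2COC[C@@H]2Cc2ccc(Cl)c(Cl)c2)cc1`: in this assay compound 3 gives 39000 nM.

Compounds 1 and 2 share one core and differ by methyl in place of methoxy on an aromatic carbon. That change gave a 1.6-fold higher number from compound 1 to compound 2 (0.20 log units; within the scatter). Compound 3 has a different core; the difference between the two cores is not broken down here. Its value is within the scatter of compound 2 but beyond the scatter of compound 1.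

Compound 4, `Cc1ccc(C[C@H]2COC[C@@H]2Cc2ccc(Cl)c(Cl)c2)cc1`, is not yet measured. It differs from compound 3 by methyl in place of methoxy on an aromatic carbon. This is the same kind of change as that from compound 1 to compound 2, but around the place it differs: in compound 1 the group sits ortho to a large group, in compound 3 para to a large group.

In this assay the step from compound 3 to compound 4 is expected to be a 1.4-fold higher number from compound 3 to compound 4 (0.15 log units; within the scatter), resting on the earlier step of a 1.6-fold higher number from compound 1 to compound 2 (0.20 log units; within the scatter), which lay within the scatter. Compound 4 is therefore estimated at 55000 nM, with a range from 25000 nM to 120000 nM.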

Compound 4, half-maximal effective concentration: 21000 nM
Beside the measured number, compound 4's estimate is 2.6-fold (0.42 log units) above it, outside the stated range (below it).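

In this assay, methyl in place of methoxy on the core of compound 3 gave a 1.9-fold lower number from compound 3 to compound 4 (0.27 log units; within the scatter), and that step alone lies within the scatter. Set beside the earlier step, however, the same change did not carry over as a fixed amount, since the two steps run in opposite directions and their gap exceeds what scatter alone would cover: the same change on two cores in this assay, a 1.6-fold higher number (0.20 log units; within the scatter) from compound 1 to compound 2 and a 1.9-fold lower number (0.27 log units; within the scatter) from compound 3 to compound 4, 2.9-fold (0.47 log units) apart, beyond the scatter of two such steps. This does not show what separates the two steps, as the pairs differ both in their core and in where the group sits on the ring, and a single pair on each core cannot tell these two differences apart.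

The compounds shown leave open whether the gap follows the core or the place of the group, which would take the same change at one place on both cores. Also open, from the compounds shown here alone, is how an amine, a carboxylic acid or a longer chain such as ethoxy at that place would read in this assay.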